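The source may report more compounds than this note shows. Statements on the series, on what has been measured and on what is new or still open speak of the compounds shown alone.

The series shares a single core, and its members differ only in the group on the amide-type nitrogen. Compound 1 `O=C(Nc1ccc(Cl)cc1)c1c(NO)cc(-c2ccccc2)oc1=O` bears a 4-chlorophenyl there. In an ADME assay on Huh-7 cells (Homo sapiens) for cytotoxicity, read by a luciferase reporter and WST assay, with a stated time of 3 days (a lower number here means that less compound is tolerated, a higher number that more compound is tolerated), compound 1 gives > 20000 nM, which is a limit of the assay rather than a number. Compound 2 `COC(=O)CNC(=O)c1c(NO)cc(-c2ccccc2)oc1=O` carries a (methoxycarbonyl)methyl on that nitrogen instead. In this assay compound 2 gives > 20000 nM, again a limit and not a number. The step that the two limits leave unreadable from compound 1 to compound 2 therefore cannot be read, and compound 2 stands exactly where the whole record stands so far, namely at the limit of > 20000 nM in this assay, at which 2 of the 2 values shown sit. Compound 3 `O=C(NCc1ccccc1)c1c(NO)cc(-c2ccccc2)oc1=O` has not yet been measured; it differs from compound 2 by phenyl in place of methoxycarbonyl on a saturated chain carbon bound to an amide-type nitrogen. Within the data shown here, the one measured step changes the substituent on the same nitrogen yet yields no size, so nothing in the record gives grounds to expect compound 3 to leave the limit. One expects the step that the limit leaves unreadable from compound 2 to compound 3 to be nothing beyond the scatter. For compound 3 one estimates 30000 nM in this assay, with a range from 12000 nM to 80000 nM, and most likely only a limit will be reported.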

Compound 3, half-maximal cytotoxic concentration: > 20000 nM
Compound 3: a limit, no number; the forecaster's own chance of this, stated with the estimate: 80%; the middle value lies beyond the limit too.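

In this assay compound 3 gives > 20000 nM, which is a limit of the assay and not a number. Among these compounds, no step among compound 1, compound 2 and compound 3 can be read. The compounds shown leave open at what concentration any of them becomes cytotoxic, and whether the group on the amide-type nitrogen changes that concentration at all: the limit of > 20000 nM in this assay, at which 3 of the 3 values shown sit.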